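This account rests on a few compounds, and the source may have more. Where it says the series, first, only, none or still open, it means among the compounds named here.

In a functional assay on HT-29 cells (Homo sapiens) for antiproliferative activity, read by sulforhodamine B assay, with a stated time of 48 h (on this read-out higher numbers stand for weaker inhibition and lower numbers for stronger inhibition), compound 3 (`CCCN1CCN(c2ccc(S(=O)(=O)Oc3ccc(C)cc3)cc2)C1=O`) gives 25000 nM, the middle of three numbers: compound 1 (`CN1CCN(c2ccc(S(=O)(=O)Oc3ccc(Cl)cc3)cc2)C1=O`) lies lower at 12000 nM and compound 2 (`CCCN1CCN(c2ccc(S(=O)(=O)Oc3cccc(C)c3)cc2)C1=O`) lies higher at 65000 nM. Compound 4 (`CCCN1CCN(c2ccc(S(=O)(=O)Oc3ccc(Cl)cc3)cc2)C1=O`) differs from compound 3 by chloro in place of methyl on an aromatic carbon, para to a large group, turning 4-methylphenyl into 4-chlorophenyl. Among the measured compounds shown here, only one measured step touches this aromatic ring, a 2.6-fold lower number from compound 2 to compound 3 (0.41 log units; beyond the scatter). That modest step relocates the methyl rather than exchanging it, so it bears only indirectly. The closest guide is compound 1 at 12000 nM, which already has the 4-chlorophenyl but carries methyl where compound 4 carries propyl, so the two differences cannot be separated. A modest move to a lower number is therefore expected in this assay, though a result within the scatter remains possible. The expected change is a 1.6-fold lower number from compound 3 to compound 4 (0.19 log units; within the scatter). For compound 4 the estimated value is 16000 nM, with an expected range of 7000 nM to 35000 nM.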

Compound 4, half-maximal inhibitory concentration: 15000 nM
For compound 4 the middle estimate is 1.1-fold (0.03 log units) above the measured one; the measured number falls inside the stated range.
By their numbers in this assay, from the lowest: compounds 1, 4 and 3 (each within the scatter of the next, the first and the last beyond it); then compound 2.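

In this assay the exchange of 4-methylphenyl for 4-chlorophenyl gives a 1.7-fold lower number from compound 3 to compound 4 (0.22 log units; within the scatter) and so does not separate methyl from chloro at this position. With the 4-chlorophenyl in place, a 1.3-fold higher number from compound 1 to compound 4 (0.10 log units; within the scatter) also leaves the chain on the amide-type nitrogen without a readable effect, which settles the question compound 1 alone left unresolved. Among the compounds shown here, the only new step beyond the scatter is a 4.3-fold lower number from compound 2 to compound 4 (0.64 log units; beyond the scatter) and it changes both the group and its place on the ring, so it cannot be assigned to either change alone.

No evidence on the cause of these differences is available. Open questions are whether fluoro, methoxy or a carboxylic acid at this position would give a number beyond the scatter, and whether a chain longer than propyl would do so.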